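Same swap, second core: an expected permeability

The source may report more compounds than this note shows. Statements on the series, on what has been measured and on what is new or still open speak of the compounds shown alone.

Compound 1 `COc1cccc(CNCCCNc2ccnc3cc(Cc4cccc(C(F)(F)F)c4)ccc23)c1O` gives 23 10^-6 cm/s in an ADME assay for permeability, using PAMPA, with a stated time of 30 min, at pH 7.4; a lower number here means that the compound crosses the layer more slowly, a higher number that the compound crosses the layer faster.
Compound 2 `COc1cccc(CNCCCNc2ccnc3cc(Cc4ccc(C#N)cc4)ccc23)c1O` gives 23 10^-6 cm/s in this assay.
Compound 3 `N#Cc1ccc(Cc2ccc3c(NCCCNCc4ccco4)ccnc3c2)cc1` gives 23 10^-6 cm/s in this assay.

All three measured compounds sit level with one another in this assay. Compound 2 and compound 1 differ in one place: 3-(trifluoromethyl)phenyl in place of 4-cyanophenyl on a saturated chain carbon bound to an aromatic carbon. That step, no change at the digits printed from compound 2 to compound 1 (within the scatter), left the read-out where it was. Compound 3 carries a different core from compound 2, and the difference is furan-2-yl in place of 2-hydroxy-3-methoxyphenyl on a saturated chain carbon bound to an amine nitrogen; this change, too, gave no change at the digits printed from compound 2 to compound 3 (within the scatter).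

Compound 4 `FC(F)(F)c1cccc(Cc2ccc3c(NCCCNCc4ccco4)ccnc3c2)c1` has not yet been measured in this assay. It differs from compound 3 in exactly the way compound 1 differs from compound 2: 3-(trifluoromethyl)phenyl in place of 4-cyanophenyl on a saturated chain carbon bound to an aromatic carbon. The place of the change is the same in both pairs, a saturated chain carbon bound to an aromatic carbon, so this is the same change, now made on the core of compound 3 rather than on the core of compound 2.

The one earlier occurrence of this change gave no change within the scatter, and the two cores themselves also sit level. On that basis the step from compound 3 to compound 4 in this assay is expected to be no change at the digits printed from compound 3 to compound 4 (within the scatter), because no change at the digits printed from compound 2 to compound 1 (within the scatter) shows the same swap leaving the read-out unmoved, and compound 3 starts from 23 10^-6 cm/s. The estimate for compound 4 in this assay is therefore 23 10^-6 cm/s, with a likely range from 12 10^-6 cm/s to 45 10^-6 cm/s.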

Compound 4, apparent permeability: 23 10^-6 cm/s
Compound 4: the middle estimate sits on the measured number at the digits printed, within the range that was stated.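

In this assay, putting 3-(trifluoromethyl)phenyl in place of 4-cyanophenyl on a saturated chain carbon bound to an aromatic carbon gave no change at the digits printed from compound 3 to compound 4 (within the scatter), and this step matches the one made on the other core: the same change on two cores in this assay, no change at the digits printed (within the scatter) from compound 2 to compound 1 and no change at the digits printed (within the scatter) from compound 3 to compound 4, 1.0-fold (0.00 log units) apart, within the scatter of two such steps

The second change, furan-2-yl in place of 2-hydroxy-3-methoxyphenyl on a saturated chain carbon bound to an amine nitrogen, gave no change at the digits printed from compound 1 to compound 4 (within the scatter), and it also reads the same in both settings: the same change on two cores in this assay, no change at the digits printed (within the scatter) from compound 2 to compound 3 and no change at the digits printed (within the scatter) from compound 1 to compound 4, 1.0-fold (0.00 log units) apart, within the scatter of two such steps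

Among these compounds, each change therefore carried from one core to the other in these four compounds, but this agreement rests on only two pairs of steps, all with a read-out that stayed level, and it does not show that either change would behave the same way on a third core or in a different assay, nor how a change that did move the read-out would carry over.

Still open, from the compounds shown here alone, is whether a carboxylic acid or an amine in place of the 4-cyanophenyl or 3-(trifluoromethyl)phenyl group would leave the read-out level as these two groups do. Going by these compounds, a longer chain than the one shared by all four compounds is also open, as is whether any such change would give the same step on both cores.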